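The source may hold more compounds than are shown below. What is called first, only, known or untested is meant among the compounds shown, and "the series" means these compounds.

Compound 1, `COc1ccc(N2C[C@@H](C)N[C@@H](C)C2)cc1NS(=O)(=O)c1ccc(-n2cccn2)cc1`: in a functional assay for agonist activity at growth hormone secretagogue receptor type 1 (Homo sapiens), read by FLIPR (a higher number here means a larger maximal response, a lower number a smaller maximal response), compound 1 gives 0.8.
Compound 2, `COc1ccc(N2C[C@@H](C)N[C@@H](C)C2)cc1NS(=O)(=O)c1ccc(-c2cccs2)cc1`: in this assay compound 2 gives 1.
Compound 3, `COc1ccc(N2C[C@@H](C)N[C@@H](C)C2)cc1NS(=O)(=O)c1ccc(Oc2ccccc2)cc1`: in this assay compound 3 gives 0.9.

Compound 3 stands second highest of these three numbers, but only narrowly so: the two steps leading to it are a number 0.10 higher from compound 1 to compound 3 (within the scatter) and a number 0.10 lower from compound 2 to compound 3 (within the scatter), both within the scatter, so the three values are practically indistinguishable. Going by the values given here, the one change that reaches beyond the scatter is a number 0.20 higher from compound 1 to compound 2 (beyond the scatter), and even that is modest.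

Compound 4, `COc1ccc(N2C[C@@H](C)N[C@@H](C)C2)cc1NS(=O)(=O)c1ccc(OCc2ccccc2)cc1`, differs from compound 3 in one place: benzyl in place of phenyl on an oxygen on an aromatic ring. Among the compounds with values here, none of the measured steps makes exactly this change, but all three concern the same outer part of the shared core, and they show that swapping groups there moved the maximal response little. On that basis the step of no change at the digits printed from compound 3 to compound 4 (within the scatter) is expected to stay within the scatter, with no clear direction. Compound 4 is therefore estimated at 0.9 in this assay, most likely between 0.7 and 1.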

Compound 4, intrinsic activity: the largest response reached, as a fraction of the reference agonist's: 0.8
Estimate against measurement, compound 4: 0.10 above; the range from low to high includes it.
By their numbers in this assay, from the lowest: compounds 1, 4, 3 and 2 (each within the scatter of the next, the first and the last beyond it).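

In this assay, going by these compounds alone, benzyl in place of phenyl on the oxygen on an aromatic ring gives a number 0.10 lower from compound 3 to compound 4 (within the scatter) and so adds a first direct reading at this oxygen: the maximal response stays level across this change, and the ring on the oxygen can sit one carbon further out without a measurable shift. The benzyloxy group also gives no change at the digits printed from compound 1 to compound 4 (within the scatter) when it replaces 1H-pyrazol-1-yl, while replacing thiophen-2-yl gives a number 0.20 lower from compound 2 to compound 4 (beyond the scatter) and so adds a second modest step beyond the scatter, both of them involving compound 2, although the step between compound 2 and compound 3 remains within the scatter. Nothing available gives a reason for these small differences.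

On these data alone, every group compared at this position carries an aromatic ring, so it remains open whether the maximal response would hold with an amine, a carboxylic acid or a plain alkyl chain there, or with a longer chain such as 2-phenylethyl on the oxygen. A maximal response also says nothing about how much of each compound is needed to reach it.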